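This account rests on a few compounds, and the source may have more. Where it says the series, first, only, none or still open, it means among the compounds named here.

Measured compounds:
- compound 1, `COc1ccc(-c2cn3ccnc3c(-c3ccc4ncn(C5CCCCC5)c4c3)n2)cc1`: 35.9%
- compound 2, `c1cn2cc(-c3ccsc3)nc(-c3ccc4ncn(C5CCCCC5)c4c3)c2n1`: 6.34%
- compound 3, `Brc1ccc(-c2cn3ccnc3c(-c3ccc4ncn(C5CCCCC5)c4c3)n2)cc1`: 23.3%

In a functional assay on NCI-H226 cells (Homo sapiens) for inhibition, read by sulforhodamine B assay, with a stated time of 48 h, tested at 10 uM (a lower number here means less inhibition, a higher number more inhibition at the concentration tested (going by the name of the read-out)), compound 3 gives 23.3%, the second highest of the three numbers. Compound 1 sits above it, a number 12.6 percentage points lower from compound 1 to compound 3 (beyond the scatter), and compound 2 sits below it, a number 17 percentage points higher from compound 2 to compound 3 (beyond the scatter). Compound 4, `c1csc(-c2cn3ccnc3c(-c3ccc4ncn(C5CCCCC5)c4c3)n2)c1`, has not yet been measured in this assay. It differs from compound 3 in one place: thiophen-2-yl in place of 4-bromophenyl on an aromatic carbon.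

The step most akin to this one runs from compound 2 to compound 3, where a five-membered sulfur ring was exchanged for the 4-bromophenyl group and the number rose: a number 17 percentage points higher from compound 2 to compound 3 (beyond the scatter). The present change removes that same 4-bromophenyl group and installs a five-membered sulfur ring again, though attached through a different ring carbon. Compound 1 adds that the 4-methoxyphenyl analogue lost inhibition on going to a thiophene as well, a number 29.6 percentage points lower from compound 1 to compound 2 (beyond the scatter). A drop beyond the scatter is therefore expected, a number 14.3 percentage points lower from compound 3 to compound 4 (beyond the scatter). For compound 4 in this assay the estimated value is 9%, within a range from 0% to 25%.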

Compound 4, a percentage reported as inhibition, at one concentration (the size of the read-out at that concentration, not a potency): 17.1%
The estimate for compound 4 lay 8.1 percentage points below the measured number, within the range that was stated.
By their numbers in this assay, from the lowest: compound 2; then compounds 4 and 3 (each within the scatter of the next); then compound 1.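

In this assay the point of attachment of the thiophene turned out to matter on this aromatic carbon: thiophen-2-yl and thiophen-3-yl are not interchangeable (a number 10.8 percentage points higher from compound 2 to compound 4 (beyond the scatter)). Exchanging 4-bromophenyl for thiophen-2-yl left the number within the scatter (a number 6.2 percentage points lower from compound 3 to compound 4 (within the scatter)), so a five-membered sulfur ring at this position need not cost inhibition relative to the bromo compound, whereas the 4-methoxyphenyl compound stays clearly ahead (a number 18.8 percentage points lower from compound 1 to compound 4 (beyond the scatter)). Nothing available explains why the two thiophenes differ.

What an amine or a carboxylic acid on this aromatic carbon would do remains open, since every group shown here is an aromatic ring. The compounds shown also leave open whether a methoxy group on the thiophen-2-yl ring would raise the number as it does on the phenyl ring.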